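The source may report more compounds than this note shows. Statements on the series, on what has been measured and on what is new or still open speak of the compounds shown alone.

Measured compounds:

Compound 1 `Cc1c(F)c(Oc2cccc(C(=N)N)c2)nc(Oc2cccc([N+](=O)[O-])c2)c1F`. In an assay on isolated protein for inhibition of serine protease 1 (Bos taurus) (on this read-out lower numbers stand for stronger inhibition and higher numbers for weaker inhibition), compound 1 gives > 5000 nM, a limit of the assay rather than a number.
Compound 2 `Cc1c(F)c(Oc2cccc(N)c2)nc(Oc2cccc(C(=N)N)c2)c1F`. Compound 2 gives > 5000 nM, again a limit.
Compound 3 `Cc1c(F)c(Oc2cccc(C(=N)N)c2)nc(Oc2cccc(C(=O)N3CCOCC3)c2)c1F`. Compound 3 gives > 5000 nM, also a limit.

Compound 3 therefore stands at the limit, and so do the two other values in the series; every value sits at the limit of > 5000 nM in this assay, at which 3 of the 3 values shown sit. The steps among the measured compounds cannot be sized: a step that the two limits leave unreadable from compound 1 to compound 2, a step that the two limits leave unreadable from compound 1 to compound 3 and a step that the two limits leave unreadable from compound 2 to compound 3 are all left unreadable by the two limits that bound them.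

Compound 4 `Cc1c(F)c(Oc2cccc(CC(N)=O)c2)nc(Oc2cccc(C(=N)N)c2)c1F` is the next case. The change from compound 3 is carbamoylmethyl in place of (morpholin-4-yl)carbonyl on an aromatic carbon. Among the compounds with values here, no measured step bears on this change with a readable size; the three earlier swaps of the group on an aromatic carbon all leave the value at the limit, so they give no direction for the step. The expectation is that compound 4 will behave like compound 3 and remain near or at the limit, so the expected step that the limit leaves unreadable from compound 3 to compound 4 is none beyond the scatter. Compound 4 is estimated at 8000 nM, within the range 2000 nM to 30000 nM.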

Compound 4, inhibition constant: > 5000 nM
Compound 4 gave a limit, no number (the forecaster's own chance of this, stated with the estimate: 70%); the middle value is on the limit's open side.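

In this assay compound 4 gives > 5000 nM as a limit, not a number. No step among compound 1, compound 2, compound 3 and compound 4 can be read, and the whole set stays at one limit: the limit of > 5000 nM in this assay, at which 4 of the 4 values shown sit.

The compounds shown leave open which group on this aromatic carbon, if any, would give a readable inhibition constant.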